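Furan-2-yl for Phenyl on a Fused Triazinone Series

A few compounds are considered here, and "the series" means these few. Any claim that something is new, unique, unknown or untested is made for them only; others in the source may bear on it.

Compound 1 `Nc1nc(-c2ccccc2)cc(-c2cccc(OC(=O)N3CCCCC3)c2)n1` gives 3540 nM in an assay on isolated protein for binding affinity to adenosine receptor A1 (Homo sapiens), read by radioligand binding; on this read-out higher numbers stand for weaker inhibition and lower numbers for stronger inhibition. Compound 2 `N#CC1=C(N)Cc2nc(-c3ccccc3)nn2C1=O` gives 0.076 nM in this assay, the lowest of the two numbers and far beyond the scatter from compound 1. Among the measured compounds shown here, compound 3 `N#CC1=C(N)Cc2nc(-c3ccco3)nn2C1=O` carries furan-2-yl in place of phenyl on an aromatic carbon; no measured pair shows this change. A step of modest size is expected, more likely toward weaker inhibition than stronger, as a 2.6-fold higher number from compound 2 to compound 3 (0.42 log units; beyond the scatter). Compound 3 is therefore estimated at 0.2 nM, within a range from 0.03 nM to 1.5 nM.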

Compound 3, inhibition constant: 0.051 nM
Compound 3: the middle estimate sits 3.9-fold (0.59 log units) above what was measured; the range from low to high includes it.
By their numbers in this assay, from the lowest: compounds 3 and 2 (each within the scatter of the next); then compound 1.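

On the aromatic carbon of the five-membered aromatic ring with 3 nitrogen, furan-2-yl in place of phenyl gives a 1.5-fold lower number from compound 2 to compound 3 (0.17 log units; within the scatter) in this assay and so does not separate compound 2 and compound 3 on this read-out. This position therefore accepts a five-membered aromatic ring with 1 hetero atom as well as a six-membered aromatic ring of carbon only, with both numbers staying far from that of compound 1. No measurement at hand explains this result.

From the compounds shown here alone, whether cyclohexyl, a dimethylamino group or a butyl chain would keep the number in this range at this position remains open. Also open, going by these compounds, is whether thiophen-2-yl would behave as furan-2-yl does.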